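A few compounds are considered here, and "the series" means these few. Any claim that something is new, unique, unknown or untested is made for them only; others in the source may bear on it.

In a functional assay for inhibition, with Homo sapiens as the target (on this read-out higher numbers stand for weaker inhibition and lower numbers for stronger inhibition), compound 1 `O=C1CCc2cc(-c3csc(-c4ccccc4)n3)ccc2N1` is reported only as the limit > 10000 nM and not as a number. Compound 2 `COc1ccc(-c2nc(-c3ccc4c(c3)CCC(=O)N4)cs2)cc1` gives 9000 nM and compound 3 `COc1ccc(-c2nc(-c3ccc4c(c3)CCC(=O)N4)cs2)c(OC)c1` gives 3000 nM in the same test, which leaves compound 2 with the higher of the two actual numbers. Compound 4 `CCCCOc1cc(-c2nc(-c3ccc4c(c3)CCC(=O)N4)cs2)ccc1OC` differs from compound 2 in one place (butoxy in place of hydrogen on an aromatic carbon): butoxy in place of hydrogen on an aromatic carbon. Among the compounds with values here, two measured steps bear on this, each putting methoxy in place of hydrogen on an aromatic carbon. The first (an at least 1.1-fold lower number from compound 1 to compound 2 (0.04 log units; that floor lies within the scatter)) has a floor within the scatter, and the second (a 3.0-fold lower number from compound 2 to compound 3 (0.48 log units; beyond the scatter)) is modest but beyond it. Going by compound 3 (3000 nM), a similar modest step to a lower number is expected in this assay (a 3.0-fold lower number from compound 2 to compound 4 (0.48 log units; beyond the scatter)). For compound 4 the estimated value is 3000 nM with an expected range from 800 nM to 10000 nM in this test.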

Compound 4, half-maximal inhibitory concentration: 300 nM
Compound 4: middle estimate off by 10-fold (1.00 log units), on the high side; measured number below the stated range.
By their numbers in this assay, from the lowest: compound 4; then compound 3; then compound 2. At a limit, above all of these: compound 1.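

In this assay, butoxy in place of hydrogen on an aromatic carbon, ortho to a methoxy group, gives a 30-fold lower number from compound 2 to compound 4 (1.48 log units; beyond the scatter). This step is large, whereas the methoxy change in a 3.0-fold lower number from compound 2 to compound 3 (0.48 log units; beyond the scatter) is modest, so this position accepts a chain without any loss of inhibition. Nothing given here accounts for the size of this step. The compounds shown leave open whether a propoxy group, a longer chain or an amine at this position would give a similar number, and so how much depends on the butoxy chain itself.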